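Methyl for bromo on the aryl arm

The compounds below may be only part of what the source reports. "The series", "measured", "known", "first", "only" and "open" are said of these compounds alone.

Compound 1 `C=CCn1c(=O)/c(=C\c2cccc(Cl)c2)[nH]c(=O)/c1=C\c1ccccc1OC` and compound 2 `C=CCn1c(=O)/c(=C\c2cccc(Br)c2)[nH]c(=O)/c1=C\c1ccccc1OC` share one core and differ only at a single aromatic carbon. In a functional assay on A549 cells (Homo sapiens) for cytotoxicity, read by CCK-8 assay, with a stated time of 72 h (a lower number here means a stronger inhibitor, a higher number a weaker inhibitor), compound 1 gives 5200 nM, and compound 2 gives 5400 nM. Within the data shown here, the only measured step, a 1.0-fold higher number from compound 1 to compound 2 (0.02 log units; within the scatter), lies within the scatter. Among the measured compounds shown here, compound 2 thus carries the highest of the two numbers so far, yet compound 1 sits within the scatter of it, so no order between them can be read. Compound 3 `C=CCn1c(=O)/c(=C\c2cccc(C)c2)[nH]c(=O)/c1=C\c1ccccc1OC` is not yet measured; it carries methyl in place of bromo on an aromatic carbon, a change that, read one bond further out, is 3-bromophenyl to 3-methylphenyl. For the measured compounds named here, no measured step covers a halogen replaced by methyl; the one step at this position, between two halogens, stayed within the scatter. The step of a 1.0-fold higher number from compound 2 to compound 3 (0.01 log units; within the scatter) is therefore expected to be small, with no direction claimed. Compound 3 is expected to give about 5500 nM in this assay, within 2500 nM to 12000 nM.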

Compound 3, half-maximal inhibitory concentration: 22700 nM
The estimate for compound 3 lay 4.1-fold (0.62 log units) below the measured number; measured number outside the range, above it.
By their numbers in this assay, from the lowest: compounds 1 and 2 (each within the scatter of the next); then compound 3.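

In this assay this aromatic carbon proves sensitive to substitution, which the exchange between the two halogens did not show: methyl in place of bromo gives a 4.2-fold higher number from compound 2 to compound 3 (0.62 log units; beyond the scatter) and methyl in place of chloro gives a 4.4-fold higher number from compound 1 to compound 3 (0.64 log units; beyond the scatter), each toward a weaker inhibitor. Compound 3 therefore stands apart from compounds 1 and 2, and across these three compounds the separation lies between halogen and methyl, not between chloro and bromo. Nothing available accounts for this result.

A single methyl cannot show whether an ethyl, a methoxy, an amine or a carboxylic acid on this carbon would follow compound 3 or the halogens. On these data alone, whether fluoro or iodo would stay with chloro and bromo also remains open.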